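Limit-bound clearance from compound 2 to compound 4

The source may report more compounds than this note shows. Statements on the series, on what has been measured and on what is new or still open speak of the compounds shown alone.

Measured in an ADME assay on microsomes from liver (Homo sapiens) for pharmacokinetics; a lower number here means slower removal, a higher number faster removal of the compound:
Compound 1 `Cn1cc(-c2ncc(C#N)c(N3C[C@@H]4C[C@H]3CN4S(=O)(=O)C3CC3)n2)cn1`: < 16 mL/min/kg (a limit)
Compound 2 `C[C@@H]1C[C@H]1C(=O)N1CCN(c2nc(-c3cnn(C)c3)ncc2C#N)C[C@H]1C`: < 16 mL/min/kg (a limit)
Compound 3 `Cn1cc(-c2ncc(C#N)c(N3C[C@@H]4C[C@H]3CN4C(=O)C3CC3)n2)cn1`: < 16 mL/min/kg (a limit)

Compound 2 has no numerical value in this assay, since its < 16 mL/min/kg is a limit. What the series shows is the limit of < 16 mL/min/kg in this assay, at which 3 of the 3 values shown sit. Compound 4 `C[C@@H]1CN(c2nc(-c3cnn(C)c3)ncc2C#N)CCN1C(=O)C1(C)CC1` has the same atoms as compound 2, joined differently: 1-methylcyclopropyl in place of 2-methylcyclopropyl on a carbonyl carbon. In words, 1-methylcyclopropyl stands in place of 2-methylcyclopropyl on a carbonyl carbon.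

Among the measured compounds shown here, only one measured step exists, a step that the two limits leave unreadable from compound 1 to compound 3. It concerns a different change, and its size cannot be read, so it gives no measure for this one. No step beyond the scatter is therefore expected, and the estimated step runs a step that the limit leaves unreadable from compound 2 to compound 4. The expectation rests on compound 2 with its limit of < 16 mL/min/kg. Compound 4 is expected at 12 mL/min/kg, with an estimated range from 7 mL/min/kg to 20 mL/min/kg.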

Compound 4, clearance: < 16 mL/min/kg
Compound 4 gave a limit, no number; the forecaster's own chance of this, stated with the estimate: 70%; the middle value lies beyond the limit too.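

In this assay, compound 2 and compound 4 both give a limit rather than a number, so no step can be read for 1-methylcyclopropyl in place of 2-methylcyclopropyl: the limit of < 16 mL/min/kg in this assay, at which 4 of the 4 values shown sit. Going by these compounds, how far each compound lies beyond that limit, and whether the two differ at all, stays open.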